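This account rests on a few compounds, and the source may have more. Where it says the series, first, only, none or still open, it means among the compounds named here.

Working notes on the solubility series.

Compound 1 `Cc1cnc(Nc2ccc(C(=O)NCC3(c4nc(-c5ccccc5)cs4)CCOCC3)cc2)s1` is read in a physicochemical assay for solubility, read by chemiluminescence, in phosphate buffer, measured as kinetic solubility, at pH 7.4; on this read-out lower numbers stand for lower solubility and higher numbers for higher solubility. In this assay compound 1 gives only a limit of the assay, < 1000 nM, and no number. Compound 2 `O=C(NCC1(c2nc(-c3ccccc3)cs2)CCOCC1)c1ccc(Nc2nc3ccccc3s2)cc1` carries a 1,3-benzothiazol-2-yl on the same aromatic nitrogen; in this assay compound 2 gives 4000 nM. Among the measured compounds shown here, the one measured step that starts from compound 1 is therefore an at least 4.0-fold higher number from compound 1 to compound 2 (0.60 log units; beyond the scatter), and its size is known only as a lower bound because compound 1 sits at the limit of < 1000 nM in this assay, at which 1 of the 3 values shown sits. For the measured compounds named here, compound 3 `COc1ccccc1-c1csc(C2(CNC(=O)c3ccc(Cn4nc(C)cc4C)cc3)CCOCC2)n1` differs from both in more than one place; in this assay compound 3 gives 78000 nM, and no single step to it is counted here.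

Compound 4 `Cn1c(Nc2ccc(C(=O)NCC3(c4nc(-c5ccccc5)cs4)CCOCC3)cc2)nc2ccccc21` is the next member to be measured in this assay. Its change from compound 1 is 1-methyl-1H-benzimidazol-2-yl in place of 5-methyl-1,3-thiazol-2-yl on a nitrogen on an aromatic ring. As in the step to compound 2, the small five-membered ring on the aromatic nitrogen gives way to a fused bicyclic group, so the step to compound 2 is the one that bears on it, and it was at least modest and upward. The number for compound 4 is therefore expected to rise from the limit of compound 1, with an at least 3.0-fold higher number from compound 1 to compound 4 (0.47 log units; beyond the scatter) as the estimated step. Compound 4 is expected to come in at 3000 nM, with a range of 800 nM to 12000 nM.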

Compound 4, solubility: 10000 nM
Estimate against measurement, compound 4: 3.3-fold (0.52 log units) below; measured number inside the range.
By their numbers in this assay, from the lowest: compound 2; then compound 4; then compound 3. At a limit, below all of these: compound 1.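

In this assay the 1-methyl-1H-benzimidazol-2-yl on a nitrogen on an aromatic ring gives an at least 10-fold higher number from compound 1 to compound 4 (1.00 log units; beyond the scatter), so the upward reading from the 5-methyl-1,3-thiazol-2-yl is no longer confined to the 1,3-benzothiazol-2-yl and now holds for two groups that each add a six-membered aromatic ring of carbon only. The two larger groups do not read alike: 1-methyl-1H-benzimidazol-2-yl in place of 1,3-benzothiazol-2-yl gives a 2.5-fold higher number from compound 2 to compound 4 (0.40 log units; beyond the scatter), which shows that this position responds to the identity of the group as well as to the added ring. The size of the step from the 5-methyl-1,3-thiazol-2-yl group remains a lower bound, because compound 1 stands at a limit of the assay: the limit of < 1000 nM in this assay, at which 1 of the 4 values shown sits.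

The exchange between the two larger groups alters the ring atoms and the methyl on nitrogen together, so the compounds shown do not say which of these carries the difference. Also open, going by these compounds, is how an aliphatic amine or a carboxylic acid in this place would read in this assay.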